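Removing the cyclohexyl from the cyclohexylmethoxy side chain

The compounds below may be only part of what the source reports. "The series", "measured", "known", "first", "only" and "open" are said of these compounds alone.

Measured compounds:
compound 1 `O=c1c(Cc2coc3cccc(OCC4CCCCC4)c3c2=O)coc2ccccc12`: 4110 nM
compound 2 `COc1ccc2c(=O)c(Cc3coc4cccc(OCC5CCCCC5)c4c3=O)coc2c1`: 1200 nM
compound 3 `Cc1ccc2c(=O)c(Cc3coc4cccc(OCC5CCCCC5)c4c3=O)coc2c1`: 3320 nM

All three were run in a functional assay on MDA-MB-231 cells (Homo sapiens) for antiproliferative activity, read by XTT assay; a higher number here means a weaker inhibitor, a lower number a stronger inhibitor. Compound 1 gives the highest of the three numbers; compound 3 sits within the scatter of it, and compound 2 gives the lowest number of the set. The steps seen so far all concern a substituent on the other aromatic ring of the shared core: a 3.4-fold lower number from compound 1 to compound 2 (0.53 log units; beyond the scatter), a 1.2-fold lower number from compound 1 to compound 3 (0.09 log units; within the scatter) and a 2.8-fold higher number from compound 2 to compound 3 (0.44 log units; beyond the scatter).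

Compound 4 `COc1cccc2occ(Cc3coc4ccccc4c3=O)c(=O)c12` arises from compound 1 by a change of a different kind: hydrogen in place of cyclohexyl on a saturated chain carbon bound to an oxygen on an aromatic ring. Among the measured compounds shown here, none of the measured steps touches this place; every compound measured so far carries the full cyclohexylmethoxy group, so no step bears directly on its removal, and the three numbers at hand only show the band in which the intact side chain lands. With nothing to lean on, the expectation for compound 4 is a step of a 2.2-fold higher number from compound 1 to compound 4 (0.34 log units; beyond the scatter), carried with a wide range. In this assay compound 4 is therefore estimated at 9000 nM, expected between 2500 nM and 35000 nM.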

Compound 4, half-maximal inhibitory concentration: > 10000 nM
Compound 4: only a limit was reported; the forecaster's own chance of this, stated with the estimate: 20%; middle value at least 1.1-fold (0.04 log units) from the limit.
By their numbers in this assay, from the lowest: compound 2; then compounds 3 and 1 (each within the scatter of the next). At a limit, above all of these: compound 4.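

Side chain, notes: in this assay, compound 4 keeps only a methoxy where compound 1 carries cyclohexylmethoxy, and its reported value is a limit, not a number: the limit of > 10000 nM in this assay, at which 1 of the 4 values shown sits.

Among the compounds shown here, removing the cyclohexyl gives an at least 2.4-fold higher number from compound 1 to compound 4 (0.38 log units; beyond the scatter), the first measured step at this place on the saturated chain carbon, and only the lower end of its size can be read. For the compounds shown here, all three compounds with the intact cyclohexylmethoxy group return a number in this assay, whereas the one compound without the cyclohexyl returns only a limit, so the cyclohexyl matters to the read-out here and the series cannot be taken to depend solely on substituents elsewhere on the shared core.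

The compounds shown do not say whether the ring itself is needed: a phenyl or a straight hexyl chain in place of cyclohexyl would separate the ring from the mere length of the chain. Also open, on these data alone, is whether a terminal amine or carboxylic acid on the chain would be tolerated, and whether the methoxy of compound 2 still lowers the number once the cyclohexyl is gone.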